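Carboxy for chloro on the benzoyl ring of compound 1

The compounds below may be only part of what the source reports. "The series", "measured", "known", "first", "only" and "open" are said of these compounds alone.

Measured compounds:
Compound 1 `COc1ccc(/C=C(/SCc2ccc(Cl)cc2)C(=O)c2ccc(Cl)cc2)cc1` — 10000 nM
Compound 2 `Cc1cc(C)cc(/C=C(/SCc2ccc(Cl)cc2)C(=O)c2ccc(Cl)cc2)c1` — 10000 nM
Compound 3 `Cc1ccc(C)c(/C=C(/SCc2ccc(Cl)cc2)C(=O)c2ccc(Cl)cc2)c1` — 10000 nM

In a functional assay on DU-145 cells (Homo sapiens) for inhibition, read by trypan blue exclusion, with a stated time of 96 h (a lower number here means a stronger inhibitor of growth, a higher number a weaker inhibitor of growth), compound 1 gives 10000 nM, level with compounds 2 and 3 at the digits shown. The steps of no change at the digits printed from compound 1 to compound 2 (within the scatter) and no change at the digits printed from compound 1 to compound 3 (within the scatter) both replace the 4-methoxyphenyl group on a double-bonded chain carbon bound to a double-bonded chain carbon, and no change at the digits printed from compound 2 to compound 3 (within the scatter) shifts the two methyl groups on that ring; none of the three moves the read-out beyond the scatter.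

Compound 4 `COc1ccc(/C=C(/SCc2ccc(Cl)cc2)C(=O)c2ccc(C(=O)O)cc2)cc1` differs from compound 1 by carboxy in place of chloro on an aromatic carbon. Among the compounds with values here, this change sits on the benzoyl ring, not on the ring where the three measured steps were made, so no measured step bears on it directly. What the measured series does show is a flat profile: three different aryl groups on the chain carbon all give the same read-out. Without any step at the chloro position there is no basis to expect a move in either direction, and the flat set of steps from compound 1 to compounds 2 and 3 argues for an unchanged value.

For compound 4 the expected step is no change at the digits printed from compound 1 to compound 4 (within the scatter), with an estimated value of 10000 nM, in the range 4000 nM to 25000 nM.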

Compound 4, concentration for 50% growth inhibition: 10000 nM
Estimate against measurement, compound 4: no gap at the digits printed; measured number inside the range.
By their numbers in this assay, from the lowest: compounds 1, 2, 3 and 4 (each within the scatter of the next).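

In this assay, within the data shown here, the replacement of 4-chlorophenyl by 4-carboxyphenyl reads no change at the digits printed from compound 1 to compound 4 (within the scatter) and adds a reading at a site away from the 4-methoxyphenyl group, the only place varied in the earlier steps. Carboxy in place of chloro, on an aromatic carbon para to a large group, brings in more heavy atoms, a hydrogen-bond donor and a hydrogen-bond acceptor, yet the read-out prints the same number as for the other three compounds. The flat profile therefore holds at a second place on the shared core, and no measurement given here accounts for this result.

The compounds shown leave open whether any other group at this position, such as an amine, a methyl ester or a nitrile, would give a printed number different from the one shared by all four compounds. Also open, from the compounds shown here alone, is how this position behaves alongside the other aryl groups, for example carboxy combined with 3,5-dimethylphenyl or 2,5-dimethylphenyl, and whether replacing the chloro on the other 4-chlorophenyl-bearing arm of the core with fluoro or an amine would move the read-out.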